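The source may hold more compounds than are shown below. What is called first, only, known or untested is meant among the compounds shown, and "the series" means these compounds.

In a physicochemical assay for solubility (a lower number here means a less soluble compound, a higher number a more soluble compound), compound 1 `O=C(O)c1ccc(C(=O)/C(=C\c2ccc(F)c([N+](=O)[O-])c2)S(=O)(=O)Cc2ccc(Br)cc2)cc1` gives < 1000 ug/mL, which is a limit and not a number. Compound 2 `O=C(O)c1ccc(C(=O)/C(=C\c2ccc(Cl)c([N+](=O)[O-])c2)SCc2ccc(Br)cc2)cc1` gives < 1000 ug/mL, also a limit, so compound 2 has no numeric standing. Both readings sit together: the limit of < 1000 ug/mL in this assay, at which 2 of the 2 values shown sit. Compound 3 `O=C(O)c1ccc(C(=O)/C(=C\c2ccc(Cl)c([N+](=O)[O-])c2)S(=O)(=O)Cc2ccc(Br)cc2)cc1` carries (4-bromobenzyl)sulfonyl in place of (4-bromobenzyl)sulfanyl on a double-bonded chain carbon bound to a carbonyl carbon and a double-bonded chain carbon. Among the measured compounds shown here, no measured step exists, and no step beyond the scatter is expected in this assay. The expected change is a step that the limit leaves unreadable from compound 2 to compound 3. Compound 3 is estimated at 600 ug/mL, with an expected range of 150 ug/mL to 1000 ug/mL.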

Compound 3, solubility: < 1000 ug/mL
Compound 3: a limit, no number; the forecaster's own chance of this, stated with the estimate: 85%; the middle value lies beyond the limit too.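

No step can be read among compound 1, compound 2 and compound 3 in this assay, because all three readings are limits, not numbers: the limit of < 1000 ug/mL in this assay, at which 3 of the 3 values shown sit. The compounds shown leave open whether (4-bromobenzyl)sulfonyl in place of (4-bromobenzyl)sulfanyl, or chloro in place of fluoro, changes the solubility read-out at all.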